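A dihydropyridine ester traded for a tert-butyl amide

A few compounds are considered here, and "the series" means these few. Any claim that something is new, unique, unknown or untested is made for them only; others in the source may bear on it.

Compound 1, with the structure `CCO/C(O)=C1\C(COCCn2c(C)nc(C)c2C)=NC(C)=C(C(=O)OC)C1c1ccccc1Cl`, is one of two measured compounds in a functional assay for inhibition of platelet-activating factor receptor (Homo sapiens) (a higher number here means a weaker inhibitor, a lower number a stronger inhibitor), where compound 1 gives 21 nM. Its partner, compound 2, drawn as `CCO/C(O)=C1\C(COCCn2c(C)nc(C)c2C)=NC(C)=C(C(=O)OC)[C@H]1c1ccccc1Cl`, has the same atoms and bonds and differs only in that a stereocentre at a saturated ring carbon is drawn with a defined configuration; in this assay compound 2 gives 15 nM. The step of a 1.4-fold lower number from compound 1 to compound 2 (0.15 log units; within the scatter) is the only measured one, and it stays within the scatter, so compound 1 stands with the higher of two numbers that cannot be told apart; because of the fact that one of compounds 1 and 2 is drawn with a defined configuration and the other without, at the place where they differ the pair says nothing about a change in substituents.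

Compound 3, with the structure `CCO/C(O)=C1\C(COCCn2c(C)nc(C)c2C)=NC(C)=C(C(=O)NC(C)(C)C)C1c1ccccc1Cl`, differs from compound 1 by (tert-butyl)amino in place of methoxy on a carbonyl carbon. Going by the values given here, no measured step touches a change at the carbonyl carbon, so the direction of the step in this assay cannot be read from the data, and no step beyond the scatter is expected with confidence. Compound 3 is therefore estimated at 30 nM, within a wide range of 5 nM to 200 nM, meaning an expected step of a 1.4-fold higher number from compound 1 to compound 3 (0.15 log units; within the scatter).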

Compound 3, half-maximal inhibitory concentration: 22 nM
Estimate against measurement, compound 3: 1.4-fold (0.13 log units) above; the measured number falls inside the stated range.
By their numbers in this assay, from the lowest: compounds 2, 1 and 3 (each within the scatter of the next).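

In this assay, putting (tert-butyl)amino in place of methoxy on a carbonyl carbon gives a 1.0-fold higher number from compound 1 to compound 3 (0.02 log units; within the scatter), so the two compounds cannot be told apart. Going by these compounds alone, this is the first measured change of an actual substituent, since the earlier pair has the same atoms and bonds, and it shows that at this position a group of 5 heavy atoms with a hydrogen-bond donor can stand in place of a group of 2 heavy atoms with none, with the number staying within the usual scatter. Nothing in the data shown accounts for this result or ties it to any property of either group.

With a single substituent swap at this carbonyl carbon, the compounds shown cannot separate the part played by the amide hydrogen from that of the tert-butyl group, which a simple methylamino group on the same carbon would begin to address. Also open, from the compounds shown here alone, is how a carboxylic acid at this place, or an ester with a longer chain than methoxy, would read in this assay.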